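The compounds below may be only part of what the source reports. "The series", "measured", "known", "first", "only" and "open" are said of these compounds alone.

Measured so far in a functional assay on HepG2 cells (Homo sapiens) for inhibition, read by MTT assay, with a stated time of 72 h; a lower number here means a stronger inhibitor, a higher number a weaker inhibitor:
compound 1 `CN(C(=O)NC(=O)c1ccc(Cl)cc1Cl)c1nc(C(F)(F)F)c(C(=O)N/N=C/c2cccc(C(F)(F)F)c2)s1` gives 11.2 ug/mL
compound 2 `CN(C(=O)NC(=O)c1ccc(Cl)cc1Cl)c1nc(C(F)(F)F)c(C(=O)N/N=C/c2ccccc2C(F)(F)F)s1` gives 10.7 ug/mL

For the measured compounds named here, compound 2 has the lowest of the two numbers, but its only neighbour, compound 1, sits right beside it: a 1.0-fold lower number from compound 1 to compound 2 (0.02 log units; within the scatter), so the two cannot be told apart. That single step swaps the aryl group on the carbon with a double bond to nitrogen and changes nothing else.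

Compound 3 `CN(C(=O)NC(=O)c1ccc(C(F)(F)F)cc1)c1nc(C(F)(F)F)c(C(=O)N/N=C/c2ccccc2C(F)(F)F)s1` has not yet been measured. It differs from compound 2 at a different place on the shared core: 4-(trifluoromethyl)phenyl in place of 2,4-dichlorophenyl on a carbonyl carbon. Going by the values given here, no measured step touches this carbonyl-bound aryl group; the only step available concerns the other end of the molecule and stayed within the scatter. With nothing in the data pointing up or down, the expected change is a 1.0-fold higher number from compound 2 to compound 3 (0.01 log units; within the scatter) in this assay, meaning no movement beyond the scatter, and the range is set wide to reflect that lack of guidance. Compound 3 is therefore estimated at 11 ug/mL, between 4.5 ug/mL and 27 ug/mL.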

Compound 3, half-maximal inhibitory concentration: 3.64 ug/mL
Beside the measured number, compound 3's estimate is 3.0-fold (0.48 log units) above it, and the stated range ends above it.
By their numbers in this assay, from the lowest: compound 3; then compounds 2 and 1 (each within the scatter of the next).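

In this assay, the aryl group on the carbonyl carbon, whose other neighbour is an amide-type nitrogen, turns out to affect the result: 4-(trifluoromethyl)phenyl in place of 2,4-dichlorophenyl gives a 2.9-fold lower number from compound 2 to compound 3 (0.47 log units; beyond the scatter). For the compounds shown here, this is a modest step, but unlike the change at the other end of the molecule, a 1.0-fold lower number from compound 1 to compound 2 (0.02 log units; within the scatter), it lies beyond the scatter, so this is the first place where a structural change registers as a stronger inhibitor. Nothing available explains why the number falls at this position.

Because this single step replaces the whole aryl group, it cannot show whether the lower number goes with gaining the trifluoromethyl group or with losing the 2,4-dichlorophenyl group, and a plain phenyl or a 4-chlorophenyl group on the same carbonyl carbon would help separate the two. Going by these compounds, it also remains open whether the same swap would give a similar step with the 3-(trifluoromethyl)phenyl group of compound 1 at the other end, and whether a different group here, such as 4-methoxyphenyl, would lower the number further.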